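The source may report more compounds than this note shows. Statements on the series, on what has been measured and on what is new or still open speak of the compounds shown alone.

Working notes on the series. Compound 1 `Cc1nn(C)c2c1C(c1cc(F)cc(F)c1)C(C#N)=C(N)O2` in a functional assay on NCI-H2122 cells (Homo sapiens) for inhibition, read by microscopy, with a stated time of 10 days (a lower number here means a stronger inhibitor, a higher number a weaker inhibitor), gives 4200 nM. Compound 2 `Cn1nc(-c2ccccc2)c2c1OC(N)=C(C#N)C2c1cc(F)cc(F)c1` carries the change phenyl in place of methyl on an aromatic carbon and in this assay gives 6600 nM; the step is a 1.6-fold higher number from compound 1 to compound 2 (0.20 log units; within the scatter). Compound 3 `Cc1nn(C)c2c1C(c1ccc(C#N)cc1)C(C#N)=C(N)O2` in this assay gives 5600 nM; how the core of compound 3 differs from the core of compound 1 is not broken down here. Compound 4 `Cn1nc(-c2ccccc2)c2c1OC(N)=C(C#N)C2c1ccc(C#N)cc1` is not yet measured in this assay. It differs from compound 3 by phenyl in place of methyl on an aromatic carbon, the same change at the same place as seen on the other core. The expected step in this assay is a 1.6-fold higher number from compound 3 to compound 4 (0.21 log units; within the scatter), which rests on the earlier measured step of a 1.6-fold higher number from compound 1 to compound 2 (0.20 log units; within the scatter) staying within the scatter. Compound 4 is therefore estimated at 9000 nM, with a likely range from 4000 nM to 20000 nM.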

Compound 4, half-maximal inhibitory concentration: 5200 nM
Estimate against measurement, compound 4: 1.7-fold (0.24 log units) above; measured number inside the range.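

In this assay, phenyl in place of methyl on an aromatic carbon gives a 1.1-fold lower number from compound 3 to compound 4 (0.03 log units; within the scatter), and the two cores agree: the same change on two cores in this assay, a 1.6-fold higher number (0.20 log units; within the scatter) from compound 1 to compound 2 and a 1.1-fold lower number (0.03 log units; within the scatter) from compound 3 to compound 4, 1.7-fold (0.23 log units) apart, within the scatter of two such steps. On the aromatic carbon, the change therefore carries from the core of compound 1 to the core of compound 3 without a step beyond the scatter, and 4-cyanophenyl in place of 3,5-difluorophenyl on a saturated ring carbon gives a 1.3-fold lower number from compound 2 to compound 4 (0.10 log units; within the scatter). Among these compounds, this shows only that the change stays within the scatter on these two cores; with no step beyond the scatter, it does not show that a larger effect would carry over, nor how other cores behave.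

On these data alone, whether an amine, a carboxylic acid or a longer chain at that aromatic carbon would move the number beyond the scatter remains open. The same holds for any group other than 3,5-difluorophenyl and 4-cyanophenyl on the saturated ring carbon.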